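Bromo added to the 3-chlorophenyl sulfonyl compound

The source may report more compounds than this note shows. Statements on the series, on what has been measured and on what is new or still open speak of the compounds shown alone.

In an ADME assay on HCT-116 cells (Homo sapiens) for cytotoxicity, read by CellTiter-Glo, with a stated time of 72 h (on this read-out lower numbers stand for stronger inhibition and higher numbers for weaker inhibition), compound 1 `Cc1ccc(S(=O)(=O)N2CCC(N3CCC(C)CC3)CC2)cc1C` reads > 5000 nM, which is a limit of the assay and not a number. Compound 2 `CC1CCN(C2CCN(S(=O)(=O)c3cccc(Cl)c3)CC2)CC1` reads > 5000 nM, again only a limit. Compound 3 `CC1CCN(C2CCN(S(=O)(=O)c3ccc(Br)c(Cl)c3)CC2)CC1` differs from compound 2 by one change: bromo in place of hydrogen on an aromatic carbon, so 3-chlorophenyl becomes 4-bromo-3-chlorophenyl. Within the data shown here, the one measured step is a step that the two limits leave unreadable from compound 1 to compound 2, which offers neither size nor direction. Among the measured compounds shown here, the series so far shows only (the limit of > 5000 nM in this assay, at which 2 of the 2 values shown sit). No change beyond the scatter is expected, and the estimated step that the limit leaves unreadable from compound 2 to compound 3 has no firm direction. Compound 3 is expected at 6000 nM, with an estimated range of 2500 nM to 15000 nM.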

Compound 3, half-maximal inhibitory concentration: > 5000 nM
Compound 3: a limit, no number; the forecaster's own chance of this, stated with the estimate: 75%; the middle value is on the limit's open side.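

Neither the step from compound 2 to compound 3 nor the step from compound 1 to compound 3 can be read in this assay: the limit of > 5000 nM in this assay, at which 3 of the 3 values shown sit.

The compounds shown leave open whether any group on the sulfonyl sulfur gives a measurable number here.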